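Swapping a nitro for dimethylamino in compound 4

A few compounds are considered here, and "the series" means these few. Any claim that something is new, unique, unknown or untested is made for them only; others in the source may bear on it.

Measured in an ADME assay on LLC-MK2 cells (Macaca mulatta) for cytotoxicity, read by MTT assay, with a stated time of 48 h; on this read-out higher numbers stand for lower toxicity in this test and lower numbers for higher toxicity in this test:
Compound 1 `C/C(=C\c1ccccc1)C(=O)/C=C/c1ccc(N(C)C)cc1`: 53000 nM
Compound 2 `C/C(=C\c1ccc([N+](=O)[O-])cc1)C(=O)/C=C/c1ccccc1`: 264000 nM
Compound 3 `C/C(=C\c1ccc([N+](=O)[O-])cc1)C(=O)/C=C/c1ccc([N+](=O)[O-])cc1`: 32500 nM

On these numbers, compound 3 stands level with compound 1 within the scatter. Among the compounds with values here, the one measured single-place step reaching it is an 8.1-fold lower number from compound 2 to compound 3 (0.91 log units; beyond the scatter), which put nitro in place of hydrogen on an aromatic carbon. Compound 4 `C/C(=C\c1ccc([N+](=O)[O-])cc1)C(=O)/C=C/c1ccc(N(C)C)cc1` differs from compound 3 by dimethylamino in place of nitro on an aromatic carbon. Within the data shown here, no measured step makes this exchange directly. However, compound 1, which carries dimethylamino, gives 53000 nM, within the scatter of compound 3, so no change beyond the scatter is expected. The expected step is a 1.2-fold higher number from compound 3 to compound 4 (0.09 log units; within the scatter). Compound 4 is estimated at 40000 nM, with an expected range of 13000 nM to 110000 nM.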

Compound 4, half-maximal cytotoxic concentration: 25900 nM
Estimate against measurement, compound 4: 1.5-fold (0.19 log units) above, and the stated range covers the measured number.
By their numbers in this assay, from the lowest: compounds 4, 3 and 1 (each within the scatter of the next, the first and the last beyond it); then compound 2.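

In this assay, nitro and dimethylamino at this position could not be told apart, the exchange giving a 1.3-fold lower number from compound 3 to compound 4 (0.10 log units; within the scatter). Set against hydrogen at the same place, dimethylamino gave a 10-fold lower number from compound 2 to compound 4 (1.01 log units; beyond the scatter), so on this core either group lowers the number well beyond the scatter. Nitro in place of hydrogen gave a 2.0-fold lower number from compound 1 to compound 4 (0.31 log units; beyond the scatter), a smaller step than on the core of compound 2: the same change on two cores in this assay, an 8.1-fold lower number (0.91 log units; beyond the scatter) from compound 2 to compound 3 and a 2.0-fold lower number (0.31 log units; beyond the scatter) from compound 1 to compound 4, 4.0-fold (0.60 log units) apart, beyond the scatter of two such steps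

The compounds shown leave open whether a carboxylic acid or a methoxy group at this position would also lower the number from that of compound 2.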